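The compounds below may be only part of what the source reports. "The series", "measured", "known", "first", "only" and "open" are said of these compounds alone.

Among the measured compounds shown here, only two compounds sharing one core have been tested so far in an ADME assay (Cricetulus griseus) for inhibition, read by CellTiter-Blue, with a stated time of 96 h; a lower number here means a stronger inhibitor, a higher number a weaker inhibitor. In this test, compound 1 `Nc1nc2[nH]c(CCCCCC(=O)N[C@@H](CCC(=O)O)C(=O)O)cc2c(=O)[nH]1` gives > 1000 nM, which is a limit of the assay and not a number. Compound 2 `Nc1nc2[nH]c(CCCCCC(=O)O)cc2c(=O)[nH]1` gives > 1000 nM, which is also a limit, so it has no exact place on the scale. The record so far is therefore (the limit of > 1000 nM in this assay, at which 2 of the 2 values shown sit).

Compound 3 `Nc1nc2[nH]c(CCCCCCC(=O)O)cc2c(=O)[nH]1` differs from compound 2 in one place: carboxymethyl in place of carboxy on a saturated chain carbon, five bonds along the chain from an aromatic carbon. Carboxymethyl stands in place of carboxy on a saturated chain carbon, five bonds along the chain from an aromatic carbon.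

For the measured compounds named here, no measured pair of compounds shows what this kind of change does. Going by the values given here, the only guide is compound 2 at > 1000 nM, itself a limit, so no change beyond the usual scatter is expected in this assay. The expected step, a step that the limit leaves unreadable from compound 2 to compound 3, is a rough estimate with no clear direction. For compound 3 the estimated value is 1500 nM, with an expected range of 800 nM to 5000 nM, and the assay may well report only a limit again.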

Compound 3, half-maximal inhibitory concentration: > 1000 nM
Compound 3: only a limit was reported (the forecaster's own chance of this, stated with the estimate: 85%); the middle value is on the limit's open side.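

Among the compounds shown here, compound 2 and compound 3 both sit at a limit of the assay and not at a number, so no step between them can be read, and the same holds for all three compounds: the limit of > 1000 nM in this assay, at which 3 of the 3 values shown sit. In this assay the compounds shown leave open whether carboxymethyl in place of carboxy changes inhibition at all, and how strongly any compound on the shared core inhibits.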